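Permeability notes: dimethylphenyl replacing chloro-trifluoromethylphenyl on the oxazole carbon

The source may hold more compounds than are shown below. What is called first, only, known or untested is meant among the compounds shown, and "the series" means these compounds.

Measured compounds:
- compound 1 `Cc1oc(-c2c(Br)cccc2Br)nc1CN1CCC(C(=O)NCCCN2C[C@H](C)C[C@H](C)C2)CC1`: < 1 10^-6 cm/s
- compound 2 `Cc1oc(-c2c(Cl)cccc2Br)nc1CN1CCC(C(=O)NCCCN2C[C@H](C)C[C@H](C)C2)CC1`: "not determined" (no result reported)
- compound 3 `Cc1oc(-c2c(Cl)cccc2C(F)(F)F)nc1CN1CCC(C(=O)NCCCN2C[C@H](C)C[C@H](C)C2)CC1`: "not determined" (no result reported)

In a physicochemical assay for permeability, using PAMPA (a lower number here means that the compound crosses the layer more slowly, a higher number that the compound crosses the layer faster), compound 1 gives only a limit, < 1 10^-6 cm/s, and not a number. For compound 2 the entry in this assay reads "not determined" (no result reported). Compound 3 likewise carries no single number in this assay; its entry reads "not determined" (no result reported). Among the measured compounds shown here, compound 3 therefore stands without a value of its own: of the three entries, one is a limit, the other two report nothing, so no measured step across the series can be drawn.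

The next compound, compound 4 `Cc1cccc(C)c1-c1nc(CN2CCC(C(=O)NCCCN3C[C@H](C)C[C@H](C)C3)CC2)c(C)o1`, differs from compound 3 in one place: 2,6-dimethylphenyl in place of 2-chloro-6-(trifluoromethyl)phenyl on an aromatic carbon.

For the measured compounds named here, with no step between measured compounds to lean on, the only anchor is the limit for compound 1, (the limit of < 1 10^-6 cm/s in this assay, at which 1 of the 3 values shown sits). Nothing measured says whether the change from compound 3 to compound 4 moves this assay beyond the scatter in either direction, so no step beyond the scatter is assumed here, and a low reading remains the nearest reference. For compound 4 the apparent permeability in this assay is estimated at 1.5 10^-6 cm/s, expected to fall between 0.5 10^-6 cm/s and 6 10^-6 cm/s, with a real chance that only a limit is reported.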

Compound 4, apparent permeability: 254 10^-6 cm/s
Compound 4: middle estimate off by 170-fold (2.23 log units), on the low side, and the stated range ends below it.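

In this assay, 2,6-dimethylphenyl in place of 2,6-dibromophenyl on an aromatic carbon of the five-membered aromatic ring gives an at least 250-fold higher number from compound 1 to compound 4 (2.40 log units; beyond the scatter), so the group at this position alone can separate a very low reading from a very high one on the shared core. Compound 1 enters this step only as a limit, so the size of the step is a lower bound and not an exact figure: the limit of < 1 10^-6 cm/s in this assay, at which 1 of the 4 values shown sits. The contrast comes from two methyl groups standing where two bromines stood, a comparison the earlier entries could not offer with a single limit and two empty results.

Any steps involving compound 2 or compound 3 cannot be read, so it remains open whether the mixed groups carrying chlorine with bromine or chlorine with trifluoromethyl sit near compound 1 or near compound 4. Also open, going by these compounds, is how a 2-methylphenyl, an unsubstituted phenyl or a 2,6-dimethoxyphenyl at the same place would read, and so whether both methyl groups are needed for the high reading.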